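The source may report more compounds than this note shows. Statements on the series, on what has been measured and on what is new or still open speak of the compounds shown alone.

Measured so far in an ADME assay on microsomes from liver (Homo sapiens) for metabolic stability, read by LC-MS, with a stated time of 30 min, tested at 1 uM; a lower number here means that less of the compound is left, a higher number that more of the compound is left:
- compound 1 (`O=C(NCc1ccc(S(=O)(=O)N2CCCCC2)cc1)c1cnc2nccn2c1`): 64%
- compound 2 (`O=C(NCc1ccc(S(=O)(=O)N2CCCCC2)cc1)c1ccc2nc[nH]c2c1`): 53%

In this assay, for the measured compounds named here, compound 2 gives 53%, the lower of the two numbers so far. Going by the values given here, the only measured step is a number 11 percentage points lower from compound 1 to compound 2 (beyond the scatter). This modest step lies beyond the scatter and puts a six-membered aromatic ring of carbon only in place of a six-membered aromatic ring with 2 hetero atoms.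

The next compound is compound 3 (`O=C(NCc1ccc(S(=O)(=O)N2CCCCC2)cc1)c1ccn2cncc2c1`), which has the same atoms as compound 2, joined differently. The change is a group of 9 heavy atoms (7 carbon, 2 nitrogen; one five-membered aromatic ring with 2 hetero atoms, one six-membered aromatic ring with 1 hetero atom) in place of a group of 9 heavy atoms (7 carbon, 2 nitrogen; one five-membered aromatic ring with 2 hetero atoms, one six-membered aromatic ring of carbon only), on a carbonyl carbon. It sits on a carbonyl carbon, as in the measured step, and its six-membered aromatic ring has 1 hetero atom. Among the compounds with values here, the step to compound 2 is the only guide, and it concerns a different pair of groups, so it supports only a weak expectation. A small rise that stays within the scatter is expected, and the estimated change is a number 3 percentage points higher from compound 2 to compound 3 (within the scatter). For compound 3 the expected value is 56%, with an estimated range from 36% to 74%.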

Compound 3, percent of the compound remaining: 54%
The estimate for compound 3 lay 2 percentage points above the measured number; measured number inside the range.
By their numbers in this assay, from the lowest: compounds 2, 3 and 1 (each within the scatter of the next, the first and the last beyond it).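

In this assay, replacing 1H-benzimidazol-6-yl on a carbonyl carbon whose other neighbour is an amide-type nitrogen with its isomer, which has 1 hetero atom in the six-membered aromatic ring, gives a number 1 percentage points higher from compound 2 to compound 3 (within the scatter), even though the entering group has 0 hydrogen-bond donors against 1 in the group it replaces. At the same place the other new step is a number 10 percentage points lower from compound 1 to compound 3 (within the scatter), so the group of compound 3 cannot be set apart from either of the other two groups, although those two lie beyond the scatter of each other. Nothing measured here offers a reason for these numbers.

Open, going by these compounds, is whether a group without a fused ring on that carbonyl carbon, such as a plain phenyl or a chain carrying an amine or a carboxylic acid, would move the number beyond the scatter of all three compounds. A single pair of isomers also cannot show whether the presence of a hydrogen-bond donor in this group matters in general.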